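The source may hold more compounds than are shown below. What is called first, only, known or untested is meant among the compounds shown, and "the series" means these compounds.

Measured in an ADME assay on microsomes from liver (Homo sapiens) for metabolic stability, with a stated time of 10 min; a lower number here means that less of the compound is left, a higher number that more of the compound is left:
- Compound 1 `O=C(O)C1CCC(O)(C(=O)N2CC[C@](c3ccc(C(F)(C(F)(F)F)C(F)(F)F)cc3)(S(=O)(=O)c3ccc(F)cc3)C2)CC1`: 100%; 95% (2 entries)
- Compound 2 `C[C@]1(C(=O)N2CC[C@](c3ccc(C(F)(C(F)(F)F)C(F)(F)F)cc3)(S(=O)(=O)c3ccc(F)cc3)C2)CC[C@@H](C(=O)O)CC1`: 85%

Compound 2 has one number in this assay, 85%, and one further entry without a single number. Compound 3 `O=C(O)C12CCC(C(=O)N3CC[C@](c4ccc(C(F)(C(F)(F)F)C(F)(F)F)cc4)(S(=O)(=O)c4ccc(F)cc4)C3)(CC1)CC2` differs from it on a carbonyl carbon: a group of 11 heavy atoms (9 carbon, 2 oxygen; 2 six-membered non-aromatic rings of carbon only) in place of a group of 10 heavy atoms (8 carbon, 2 oxygen; one six-membered non-aromatic ring of carbon only), on a carbonyl carbon. Among the measured compounds shown here, no measured step yet gauges such a change. Compound 1 at 100%; 95% (2 entries) and compound 2 at 85% both lie high on the scale, so no step beyond the scatter is expected in this assay. The expected change is no change at the digits printed from compound 2 to compound 3 (within the scatter). For compound 3 the estimated value is 85%, with an expected range of 65% to 100%.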

Compound 3, percent of the compound remaining: 100%
Estimate against measurement, compound 3: 15 percentage points below, and the stated range covers the measured number.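

In this assay, the group with 2 six-membered non-aromatic rings of carbon only, in place of 4-carboxy-1-methylcyclohexyl on the carbonyl carbon, gives a number 15 percentage points higher from compound 2 to compound 3 (beyond the scatter). Among the compounds shown here, this place on the carbonyl carbon therefore accepts the larger group with no loss of compound remaining, and compound 3 stands at 100%. The step is modest, and repeat entries on a single compound also differ at this end of the scale: the several entries of compound 1 in this assay, 100%; 95% (2 entries)

Going by these compounds, whether an amine in place of the carboxylic acid would hold this assay this high stays open. So does the effect of a longer chain between the ring and the carboxylic acid.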